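This account rests on a few compounds, and the source may have more. Where it says the series, first, only, none or still open, it means among the compounds named here.

Measured set:
compound 1 `CC(/N=c1\c(O)c(O)\c1=N/Cc1ccc(C#N)cc1Cl)C(C)(C)C` 180 nM
compound 2 `CCc1cc(C#N)ccc1C/N=c1\c(O)c(O)\c1=N/C(C)(C)C` 240 nM
compound 3 `CCc1cc(C#N)ccc1C/N=c1\c(O)c(O)\c1=N/C(C)(C)CC` 110 nM

In a functional assay for inhibition, with Rattus norvegicus as the target (a higher number here means a weaker inhibitor, a lower number a stronger inhibitor), compound 2 carries the highest of the three numbers. Compound 1 sits nearest, within the scatter, and compound 3 sits furthest, a 2.2-fold lower number from compound 2 to compound 3 (0.34 log units; beyond the scatter). For the measured compounds named here, that one step, a methyl in place of hydrogen on a saturated chain carbon, two bonds along the chain from a double-bonded nitrogen, is the only one-place change in the set and touches the chain, not the ring.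

Compound 4 `CC(C)(C)/N=c1\c(O)c(O)\c1=N/Cc1ccc(C#N)cc1Cl` differs from compound 2 in one place: chloro in place of ethyl on an aromatic carbon. Going by the values given here, no measured step bears on a change at this aromatic carbon. Compound 1 shares the chloro-bearing ring with compound 4 but differs from compound 2 in two places, so its value can only be set beside that of compound 2; the two lie within the scatter of each other. Without a step to lean on, no movement beyond the scatter is expected for this assay, and compound 4 is estimated at 200 nM (range 100 nM to 400 nM), a step of a 1.2-fold lower number from compound 2 to compound 4 (0.08 log units; within the scatter) that is expected to stay inside the scatter.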

Compound 4, half-maximal inhibitory concentration: 140 nM
Beside the measured number, compound 4's estimate is 1.4-fold (0.15 log units) above it, and the stated range covers the measured number.
By their numbers in this assay, from the lowest: compounds 3, 4, 1 and 2 (each within the scatter of the next, the first and the last beyond it).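

In this assay, for the compounds shown here, chloro in place of ethyl on this aromatic carbon gives a 1.7-fold lower number from compound 2 to compound 4 (0.23 log units; within the scatter), the first reading at this position, and the two groups cannot be told apart here. Going by these compounds alone, on the double-bonded nitrogen, tert-butyl in place of 1,2,2-trimethylpropyl gives a 1.3-fold lower number from compound 1 to compound 4 (0.11 log units; within the scatter), so this first chain change on the chloro-bearing ring also stays inside the scatter, while a 2.2-fold lower number from compound 2 to compound 3 (0.34 log units; beyond the scatter) remains the only step that clears it. Nothing available explains either new step.

From the compounds shown here alone, whether a much different group at this aromatic carbon, such as methoxy, an amine or a carboxylic acid, would move the number remains open. Also open, going by these compounds, is whether the added chain methyl would give a similar step on the chloro-bearing ring.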